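Para-substituent on the benzylidene arm: methoxy to hydroxy

The compounds below may be only part of what the source reports. "The series", "measured", "known", "first", "only" and "open" are said of these compounds alone.

Measured compounds in a functional assay on PCO3 cells (Homo sapiens) for cytotoxicity, read by sulforhodamine B assay; on this read-out higher numbers stand for weaker inhibition of growth and lower numbers for stronger inhibition of growth:
compound 1 `CC1=CC[C@@H]([C@@](C)(O)CCCC(C)(C)NC(=S)N/N=C\c2ccccc2)CC1` 36200 nM
compound 2 `CC1=CC[C@@H]([C@@](C)(O)CCCC(C)(C)NC(=S)N/N=C\c2ccc(C)cc2)CC1` 45700 nM
compound 3 `COc1ccc(/C=N\NC(=S)NC(C)(C)CCC[C@](C)(O)[C@@H]2CC=C(C)CC2)cc1` 76100 nM

Compound 3 holds the highest number of the three in this assay. Its nearest neighbour is compound 2, a step (a 1.7-fold higher number from compound 2 to compound 3 (0.22 log units; within the scatter)) that stays within the scatter; the step (a 2.1-fold higher number from compound 1 to compound 3 (0.32 log units; beyond the scatter)) to compound 1 is a modest one, beyond the scatter. Between the two smaller substituents the step (a 1.3-fold higher number from compound 1 to compound 2 (0.10 log units; within the scatter)) is within the scatter, so across these three compounds the substituent on the aromatic ring moves the number only a little.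

Compound 4 `CC1=CC[C@@H]([C@@](C)(O)CCCC(C)(C)NC(=S)N/N=C\c2ccc(O)cc2)CC1` differs from compound 3 by hydrogen in place of methyl on an oxygen on an aromatic ring. Among the measured compounds shown here, no measured step removes the methyl from the oxygen or brings in a hydroxy, so there is no direct precedent. The steps that touch the same aromatic position, (a 2.1-fold higher number from compound 1 to compound 3 (0.32 log units; beyond the scatter)) and (a 1.7-fold higher number from compound 2 to compound 3 (0.22 log units; within the scatter)), are small, which suggests that a further change at that position is unlikely to move the number far. For compound 4 the expected step is (a 1.3-fold lower number from compound 3 to compound 4 (0.10 log units; within the scatter)), within the scatter, with no direction claimed. Compound 4 is therefore estimated at 60000 nM, in the range 25000 nM to 140000 nM.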

Compound 4, concentration for total growth inhibition: 13900 nM
For compound 4 the middle estimate is 4.3-fold (0.64 log units) above the measured one, and the stated range ends above it.
By their numbers in this assay, from the lowest: compound 4; then compounds 1, 2 and 3 (each within the scatter of the next, the first and the last beyond it).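

In this assay, among the compounds shown here, hydroxy is the first group on this aromatic carbon to give a lower number beyond the scatter, and compound 4 stands apart from all three earlier compounds: from the methoxy compound (a 5.5-fold lower number from compound 3 to compound 4 (0.74 log units; beyond the scatter)), from the methyl compound (a 3.3-fold lower number from compound 2 to compound 4 (0.52 log units; beyond the scatter)) and from the unsubstituted compound (a 2.6-fold lower number from compound 1 to compound 4 (0.42 log units; beyond the scatter)). The position is therefore more responsive than the small steps among compounds 1, 2 and 3 indicated. Methoxy and hydroxy, which differ only by the methyl on the oxygen, mark the two ends of the series, so the identity of the group at this position matters even where the attached atom stays the same, though nothing measured here gives a reason for the step.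

From the compounds shown here alone, it remains open whether the lower number is specific to hydroxy or would also appear with an amine or a carboxylic acid in the same place. Going by these compounds, it is also open whether the hydroxy step would carry over to a core with a shorter or longer chain, since all four compounds share one core and one read-out.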